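Series notes: trifluoromethoxy replaced by trifluoromethyl

The compounds below may be only part of what the source reports. "The series", "measured", "known", "first", "only" and "open" are said of these compounds alone.

Three amides share one core. Compound 1 `CC(C)[C@@H](N)C(=O)NCc1ccc(C(F)(F)F)cc1` has been measured in a functional assay on the whole organism (strain albino Sprague-Dawley) with Rattus norvegicus as the target, in the maximal electroshock model (on this read-out lower numbers stand for an effect already at smaller amounts and higher numbers for an effect only at larger amounts of compound), and gives 13 mg/kg. Compound 2 `CC(C)(C)[C@@H](N)C(=O)NCc1ccc(-c2ccccc2)cc1` has no number in this assay; its entry reads "not determined" (no result reported). Compound 3 `CC(C)(C)[C@@H](N)C(=O)NCc1ccc(OC(F)(F)F)cc1` gives 23 mg/kg in this assay, the higher of the two numbers recorded so far; its nearest neighbour is compound 1, and the two values lie within the usual scatter, so no order between them can be read. For the measured compounds named here, no two measured compounds differ in a single place, so no step between measured compounds is available.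

Compound 4 `CC(C)(C)[C@@H](N)C(=O)NCc1ccc(C(F)(F)F)cc1` remains to be measured. From compound 3 it differs by trifluoromethyl in place of trifluoromethoxy on an aromatic carbon. Compound 1 also carries trifluoromethyl on the same core position and gives 13 mg/kg, which is the only point of reference for the expectation. In this assay the expected step from compound 3 to compound 4 is a 1.5-fold lower number from compound 3 to compound 4 (0.19 log units; within the scatter), that is none clearly beyond the scatter, leaning if anything toward a lower number. Compound 4 is estimated at 15 mg/kg, with a range from 7 mg/kg to 35 mg/kg.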

Compound 4, dose for half-maximal effect: < 30 mg/kg
Compound 4: no number, only a limit (the forecaster's own chance of this, stated with the estimate: 10%); the middle value lies beyond the limit too.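

In this assay compound 4 gives a limit and not a number, so no step from compound 3 or compound 1 to compound 4 can be read: the limit of < 30 mg/kg in this assay, at which 1 of the 4 values shown sits.

The compounds shown leave open whether trifluoromethyl in place of trifluoromethoxy, or methyl in place of hydrogen on the saturated chain carbon, changes the number in this assay at all.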